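Notes on the 2-amino-1,3-benzoxazol-5-yl analogue in this series

The compounds below may be only part of what the source reports. "The series", "measured", "known", "first", "only" and "open" are said of these compounds alone.

Compound 1 `CNC(=O)CCCCCCCn1nc(-c2cnc3[nH]ccc3c2)c2c(N)ncnc21`: 23500 nM
Compound 2 `Nc1ncnc2c1c(-c1cnc3[nH]ccc3c1)nn2CCCCCCC(=O)NO`: 50900 nM
Compound 3 `Nc1nc2cc(-c3nn(CCCCCC(=O)NO)c4ncnc(N)c34)ccc2o1`: 9910 nM

In a functional assay on Huh-7 cells (Homo sapiens) for inhibition, read by MTT assay, with a stated time of 72 h (a higher number here means a weaker inhibitor, a lower number a stronger inhibitor), compound 1 gives 23500 nM, the second highest of the three numbers. Compound 4 `CNC(=O)CCCCCCCn1nc(-c2ccc3oc(N)nc3c2)c2c(N)ncnc21` differs from it as follows: a group of 10 heavy atoms (7 carbon, 2 nitrogen, 1 oxygen; one five-membered aromatic ring with 2 hetero atoms, one six-membered aromatic ring of carbon only) in place of a group of 9 heavy atoms (7 carbon, 2 nitrogen; one five-membered aromatic ring with 1 hetero atom, one six-membered aromatic ring with 1 hetero atom), on an aromatic carbon. Going by the values given here, the only measured step, a 2.2-fold higher number from compound 1 to compound 2 (0.34 log units; beyond the scatter), changes the chain end and not this place, so it bears on the exchange only indirectly. Compound 3 carries the entering group and gives 9910 nM, a lower number than compound 2 at 50900 nM, though those two also differ in chain length. The expected step, toward a stronger inhibitor, is a 2.4-fold lower number from compound 1 to compound 4 (0.37 log units; beyond the scatter). For compound 4 the estimated value is 10000 nM, with an expected range of 3000 nM to 30000 nM.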

Compound 4, half-maximal inhibitory concentration: 2770 nM
The estimate for compound 4 lay 3.6-fold (0.56 log units) above the measured number, outside the stated range (below it).
By their numbers in this assay, from the lowest: compound 4; then compound 3; then compound 1; then compound 2.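

In this assay, this position now has a direct reading with the chain held constant: 2-amino-1,3-benzoxazol-5-yl in the place of the earlier group gives an 8.5-fold lower number from compound 1 to compound 4 (0.93 log units; beyond the scatter) and is beyond the scatter. The chain end also matters with this group in place, with a 3.6-fold lower number from compound 3 to compound 4 (0.55 log units; beyond the scatter) as the step, so the methylcarbamoyl end carries the lower number in both pairs that change it, compound 1 against compound 2 and compound 4 against compound 3. Nothing here bears on the cause of either step.

From the compounds shown here alone, whether the exchange holds at a matched hydroxycarbamoyl chain remains open. So does whether a carboxylic acid or an amine at the chain end would keep the lower number.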